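A Methylphenyl Ether in Place of a Chlorophenyl Ether

The source may hold more compounds than are shown below. What is called first, only, known or untested is meant among the compounds shown, and "the series" means these compounds.

Measured compounds and their values in a functional assay on SMMC-7721 cells (Homo sapiens) for antiproliferative activity, read by MTT assay, with a stated time of 72 h; on this read-out higher numbers stand for weaker inhibition and lower numbers for stronger inhibition:
compound 1 `Cc1nn(C)c(Oc2cccc(Cl)c2)c1/C=N\CCCCCCOc1cc2oc(=O)cc(C)c2cc1Cl` gives 5260 nM
compound 2 `Cc1nn(C)c(Oc2ccc(Cl)cc2)c1/C=N\CCCCCCOc1cc2oc(=O)cc(C)c2cc1Cl` gives 2080 nM
compound 3 `Cc1nn(C)c(Oc2cccc(Br)c2)c1/C=N\CCCCCCOc1cc2oc(=O)cc(C)c2cc1Cl` gives 5080 nM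

Compound 1 carries the highest number of the three in this assay and is therefore the weakest inhibitor among them. Compound 3 lies within the scatter of compound 1 (a 1.0-fold lower number from compound 1 to compound 3 (0.02 log units; within the scatter)), so the two cannot be ranked. Among the measured compounds shown here, the only change beyond the scatter is a 2.5-fold lower number from compound 1 to compound 2 (0.40 log units; beyond the scatter), a modest gain.

Compound 4 `Cc1ccc(Oc2c(/C=N\CCCCCCOc3cc4oc(=O)cc(C)c4cc3Cl)c(C)nn2C)cc1` differs from compound 1 in one place: 4-methylphenyl in place of 3-chlorophenyl on an oxygen on an aromatic ring. For the measured compounds named here, two measured steps bear on this. The first, a 2.5-fold lower number from compound 1 to compound 2 (0.40 log units; beyond the scatter), shows that shifting the chloro group on the phenyl ring gave a modest improvement. The second, a 1.0-fold lower number from compound 1 to compound 3 (0.02 log units; within the scatter), shows that swapping one halogen for another changed nothing beyond the scatter. The change to compound 4 combines a shift of position with a swap from chloro to methyl, for which no direct comparison exists. Compound 4 is therefore expected to show a modest lower number, a 2.1-fold lower number from compound 1 to compound 4 (0.32 log units; beyond the scatter), with an estimate of 2500 nM and a range from 1000 nM to 6500 nM.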

Compound 4, half-maximal inhibitory concentration: 18600 nM
Compound 4: middle estimate off by 7.4-fold (0.87 log units), on the low side; measured number outside the range, above it.
By their numbers in this assay, from the lowest: compound 2; then compounds 3 and 1 (each within the scatter of the next); then compound 4.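

In this assay, 4-methylphenyl moves the number the opposite way from what the chlorine shift in compound 2 suggested (a 3.5-fold higher number from compound 1 to compound 4 (0.55 log units; beyond the scatter); a 3.7-fold higher number from compound 3 to compound 4 (0.56 log units; beyond the scatter)), although these two steps change both the group and its place on the phenyl ring. The cleanest comparison keeps the place fixed and exchanges only chloro for methyl (an 8.9-fold higher number from compound 2 to compound 4 (0.95 log units; beyond the scatter)), the largest step in this set, so at this position methyl cannot stand in for chloro, even though bromo and chloro could not be told apart in compounds 1 and 3. No measurement at hand accounts for this difference. Still open, as far as these compounds go, is whether this weakening is specific to methyl or extends to other groups without a halogen. A methoxy group or an amine on this phenyl ring would test that.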